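Ortho-chloro for para-methoxy on the pyrimidinone aryl

The source may hold more compounds than are shown below. What is called first, only, known or untested is meant among the compounds shown, and "the series" means these compounds.

Measured so far in a functional assay, with a stated time of 20 min; on this read-out lower numbers stand for stronger inhibition and higher numbers for weaker inhibition:
compound 1 `CCOC(=O)c1cnn(-c2nc(-c3ccc(OC)cc3)c(C#N)c(=O)n2C)c1N` gives 59 ug/mL
compound 2 `COc1cccc(-c2nc(NN)n(C)c(=O)c2C#N)c1OC` gives 44 ug/mL

Compound 1 stands at the upper end of these two numbers in this assay, but compound 2 lies within the scatter of it, so the two values cannot be ordered. For the measured compounds named here, no pair of measured compounds differs in only one place, so no single-change step is available from which to read the size of a substituent swap on this core.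

Compound 3 `CCOC(=O)c1cnn(-c2nc(-c3ccccc3Cl)c(C#N)c(=O)n2C)c1N` has not been measured. It differs from compound 1 in one place: 2-chlorophenyl in place of 4-methoxyphenyl on an aromatic carbon. Going by the values given here, no measured pair speaks to this change, so nothing beyond the scatter can be expected from it in either direction; the estimate therefore stays close to the number seen for compound 1 in this assay, with a wide range to reflect the missing precedent. For compound 3 the expected step is a 1.1-fold lower number from compound 1 to compound 3 (0.03 log units; within the scatter). Compound 3 is thus estimated at 55 ug/mL in this assay, within the range 25 ug/mL to 120 ug/mL.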

Compound 3, half-maximal inhibitory concentration: 78 ug/mL
Compound 3: middle estimate off by 1.4-fold (0.15 log units), on the low side; the range from low to high includes it.
By their numbers in this assay, from the lowest: compounds 2, 1 and 3 (each within the scatter of the next).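

In this assay, for the compounds shown here, the only single-change step on this core, 2-chlorophenyl in place of 4-methoxyphenyl on the aromatic carbon next to the ring nitrogen and ortho to a cyano group, gives a 1.3-fold higher number from compound 1 to compound 3 (0.12 log units; within the scatter) and so stays within the scatter. This position therefore accepts an exchange of a group with a hydrogen-bond acceptor for one with none without a resolved shift in the read-out, although the substituent and its place on the phenyl change together and this one step cannot separate the two. No measurement of any property of these groups is available to account for the step.

As far as these compounds go, whether 4-chlorophenyl or 2-methoxyphenyl would part the identity of the substituent from its place on the phenyl stays open, as does whether a phenyl carrying an amine or a carboxylic acid would move the read-out beyond the scatter. Compound 2 differs from compound 1 and compound 3 in more than one place, so it adds no comparison on this change.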